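Urea to amide in a pyrazole series: expected growth inhibition

The source may hold more compounds than are shown below. What is called first, only, known or untested is meant among the compounds shown, and "the series" means these compounds.

Compound 1 `COc1cc(-c2nn(-c3cccc(NC(=O)Nc4cc(C(F)(F)F)cc(C(F)(F)F)c4)c3)cc2-c2ccncc2)ccc1Cl`: 363 nM
Compound 2 `COc1cc(-c2nn(-c3cccc(NC(=O)Nc4ccc(Cl)c(Cl)c4)c3)cc2-c2ccncc2)ccc1Cl`: 890 nM
Compound 3 `O=C(Nc1cccc(-n2cc(-c3ccncc3)c(-c3ccc(Cl)c(O)c3)n2)c1)Nc1ccc(Cl)c(Cl)c1`: 1410 nM

These three compounds were tested in a functional assay on K562 cells (Homo sapiens) for inhibition, read by sulforhodamine B assay, with a stated time of 48 h; a higher number here means a weaker inhibitor of growth, a lower number a stronger inhibitor of growth. Compound 2 stands second highest of the three numbers, with compound 3 nearest and compound 1 furthest. Among the measured compounds shown here, the only single-point step among them, a 1.6-fold higher number from compound 2 to compound 3 (0.20 log units; within the scatter), concerns the methoxy group on the shared core and not the urea end.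

Compound 4 `COc1cc(-c2nn(-c3cccc(NC(=O)c4ccc(Cl)c(C(F)(F)F)c4)c3)cc2-c2ccncc2)ccc1Cl` is not yet measured. It differs from compound 2 by 4-chloro-3-(trifluoromethyl)phenyl in place of (3,4-dichlorophenyl)amino on a carbonyl carbon, so the urea becomes an amide. For the measured compounds named here, no measured step touches this part of the structure; compound 1 and compound 2 differ at the same end, but their values show only that a change there can move the number beyond the scatter. With no direct guide, compound 4 is expected to sit near compound 2, a 1.1-fold higher number from compound 2 to compound 4 (0.05 log units; within the scatter), estimated at 1000 nM with a range of 300 nM to 3500 nM.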

Compound 4, concentration for 50% growth inhibition: 1610 nM
For compound 4 the middle estimate is 1.6-fold (0.21 log units) below the measured one, and the stated range covers the measured number.
By their numbers in this assay, from the lowest: compound 1; then compounds 2, 3 and 4 (each within the scatter of the next).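

In this assay, placing 4-chloro-3-(trifluoromethyl)phenyl instead of (3,4-dichlorophenyl)amino on the carbonyl carbon gives a 1.8-fold higher number from compound 2 to compound 4 (0.26 log units; within the scatter), so this urea-to-amide change stays within the scatter even though the entering group has no hydrogen-bond donor and the leaving group has one. No evidence is available to explain this result. On these data alone, the linker and the ring substituents change together, so their separate contributions remain unknown. As far as these compounds go, it also remains open how an amine or a carboxylic acid at this end would behave.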